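Swapping the Side Group: Expected Efficacy of Compound 3

A few compounds are considered here, and "the series" means these few. Any claim that something is new, unique, unknown or untested is made for them only; others in the source may bear on it.

Compound 1 `O=S(=O)(NCC1CCN(CCCc2c[nH]c3ccc(-n4cnnc4)cc23)CC1)c1ccccc1` and compound 2 `CN(Cc1cccs1)C1CCN(CCCc2c[nH]c3ccc(-n4cnnc4)cc23)CC1` share one core and differ only in the group carried on a saturated ring carbon. In a functional assay on CHO cells for activation of 5-hydroxytryptamine receptor 1D (Homo sapiens), read by GTPgammaS binding (a higher number here means a larger maximal response, a lower number a smaller maximal response), compound 1 gives 73%, and compound 2 gives 81%. Within the data shown here, the sole measured step, a number 8 percentage points higher from compound 1 to compound 2 (within the scatter), shows that exchanging the group at this position did not move the maximal response beyond the usual scatter. Compound 2 stands at the top of the two numbers, but compound 1 is within the scatter of it, so the two are not distinguished.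

Compound 3 `c1ccc2c(c1)CCC2NCC1CCN(CCCc2c[nH]c3ccc(-n4cnnc4)cc23)CC1` carries a further variation at the same position: ((2,3-dihydro-1H-inden-1-yl)amino)methyl in place of methyl((thiophen-2-yl)methyl)amino on a saturated ring carbon. Among the measured compounds shown here, the only step that bears on this change is the one between compound 1 and compound 2, which was within the scatter, and nothing measured so far points to a direction. Compound 3 is therefore expected to show a step of a number 4 percentage points lower from compound 2 to compound 3 (within the scatter) in this assay, that is, no change beyond the scatter. The efficacy of compound 3 is estimated at 77%, with a range from 60% to 93%.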

Compound 3, largest response reached (reported as efficacy), in percent of the reference or control that the assay uses: 78%
The estimate for compound 3 lay 1 percentage points below the measured number; the range from low to high includes it.
By their numbers in this assay, from the lowest: compounds 1, 3 and 2 (each within the scatter of the next).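

Exchanging methyl((thiophen-2-yl)methyl)amino for ((2,3-dihydro-1H-inden-1-yl)amino)methyl gave a number 3 percentage points lower from compound 2 to compound 3 (within the scatter) in this assay, which shows that this position, on a saturated ring carbon three ring bonds from the ring nitrogen, also accepts a group with a five-membered non-aromatic ring of carbon only and a six-membered aromatic ring of carbon only without a step beyond the scatter. The second new comparison, 2,3-dihydro-1H-inden-1-yl in place of phenylsulfonyl on an amine nitrogen, gave a number 5 percentage points higher from compound 1 to compound 3 (within the scatter), so the three compounds are not distinguished by their maximal response and the sulfonyl group is not needed for a response of this size among the compounds shown. No measured evidence on the reason for this result is available.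

All three groups at this position carry a ring, and the compounds shown leave open whether a plain amine or a carboxylic acid on a short chain would also stay within the scatter. They also leave open whether an amide in place of the amine nitrogen would do so.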